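Adding a second chloro to compound 2: expected inhibition

The source may report more compounds than this note shows. Statements on the series, on what has been measured and on what is new or still open speak of the compounds shown alone.

Two members of one series have been tested in a functional assay on the whole organism (strain Wister albino) for inhibition, with Rattus norvegicus as the target, read by paw edema, with stated times of 1 h and 4 h, at a dose of 50 mg/kg by the intraperitoneal route; a higher number here means more inhibition at the dose given (going by the name of the read-out), a lower number less inhibition. Compound 1, `CCOC(=O)c1c(-c2ccc(Cl)c(Cl)c2)cc(-c2ccccc2)nc1N1CCCCC1`, gives 64.7% in this assay. Compound 2, `CCOC(=O)c1c(-c2ccc(Cl)cc2)cc(-c2ccccc2)nc1Nc1ccc(C)cc1`, gives 61.8% in this assay. Compound 2 holds the lower of the two numbers, but its distance to compound 1 is within the scatter of repeated measurements, so the two values show no difference that can be read as real. Among the measured compounds shown here, no comparison between compounds that differ in only one place is available from these two.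

Compound 3, `CCOC(=O)c1c(-c2ccc(Cl)c(Cl)c2)cc(-c2ccccc2)nc1Nc1ccc(C)cc1`, is the next compound. It differs from compound 2 by chloro in place of hydrogen on an aromatic carbon, the change sitting on an aromatic carbon of a six-membered aromatic ring of carbon only, ortho to a chloro group; read one bond further out, 4-chlorophenyl becomes 3,4-dichlorophenyl.

Nothing measured here isolates the effect of this change. The author therefore expects the step from compound 2 to compound 3 in this assay, a number 2.2 percentage points higher from compound 2 to compound 3 (within the scatter), to stay within the scatter, with no clear direction. For compound 3 the estimate in this assay is 64%, expected to lie between 52% and 76%.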

Compound 3, a percentage reported as inhibition, in the whole organism at one dose (the size of the read-out at that dose, not a potency): 59.8%
Compound 3: middle estimate off by 4.2 percentage points, on the high side; measured number inside the range.
By their numbers in this assay, from the lowest: compounds 3, 2 and 1 (each within the scatter of the next).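

Among the compounds shown here, the pair of compound 2 and compound 3 gives the first reading of this position in this assay. With chloro in place of hydrogen on an aromatic carbon, ortho to a chloro group, 4-chlorophenyl becomes 3,4-dichlorophenyl and the record shows a number 2 percentage points lower from compound 2 to compound 3 (within the scatter) and thus no difference that can be read as real at this dose. Compound 3 also opens a second comparison at another place on the shared core, where (4-methylphenyl)amino in place of piperidin-1-yl gives a number 4.9 percentage points lower from compound 1 to compound 3 (within the scatter) and likewise no readable difference with the 3,4-dichlorophenyl group present, while no supporting evidence bears on the reason for either result.

Going by these compounds, what remains open is whether a different group at the chloro position, such as methoxy or a carboxylic acid, would shift the inhibition beyond the scatter. On these data alone, it is equally open whether morpholine or a simple primary amine in place of piperidin-1-yl or (4-methylphenyl)amino would separate from the values seen so far.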